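Replacing a Pyrimidine Ring with a Carboxypyridine

The compounds below may be only part of what the source reports. "The series", "measured", "known", "first", "only" and "open" are said of these compounds alone.

Three compounds that share one core have been examined in a physicochemical assay for solubility, using the shake flask method, in phosphate buffer, measured as kinetic solubility, with a stated time of 20 h, at pH 6.5; on this read-out higher numbers stand for higher solubility and lower numbers for lower solubility. Compound 1, `FC(F)(F)c1cccc(-c2nc3cnc(Nc4ncccn4)cc3[nH]2)c1`, gives < 5000 nM, which is a limit of the assay and not a number. Compound 2, `FC(F)(F)c1cccc(-c2nc3cnc(Nc4ccncn4)cc3[nH]2)c1`, gives < 5000 nM, again a limit rather than a number. Compound 3, `Fc1ccc(-c2nc3cnc(Nc4ccccn4)cc3[nH]2)cc1C(F)(F)F`, gives < 5000 nM, also a limit. The step that the two limits leave unreadable from compound 1 to compound 2 is unreadable: both of its ends are limits. Within the data shown here, the only evidence the measurements offer is the limit of < 5000 nM in this assay, at which 3 of the 3 values shown sit. Compound 2 therefore stands at the same limit as every other value shown, with no number of its own.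

Compound 4, `O=C(O)c1ccnc(Nc2cc3[nH]c(-c4cccc(C(F)(F)F)c4)nc3cn2)c1`, differs from compound 2 in one place: 4-carboxypyridin-2-yl in place of pyrimidin-4-yl on a nitrogen on an aromatic ring. No measured step bears on this change, since the single step shown, a step that the two limits leave unreadable from compound 1 to compound 2, has no readable size or direction. Any expectation for compound 4 in this assay must rest on that limit alone, so the direction of the step is open and its size is uncertain. Compound 4 is expected to give 20000 nM, with a range from 3000 nM to 150000 nM. The step this estimate means, an at least 4.0-fold higher number from compound 2 to compound 4 (0.60 log units; beyond the scatter), is an expectation and not a measurement.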

Compound 4, solubility: < 5000 nM
Compound 4: no number, only a limit; the forecaster's own chance of this, stated with the estimate: 35%; at least 4.0-fold (0.60 log units) between middle value and limit.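

In this assay compound 4 gives < 5000 nM as a limit and not a number. The steps to compound 4 from compound 1 and from compound 2 cannot be read: each has a limit at both ends. The compounds shown leave open how these compounds truly differ on this read-out, in both direction and size.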